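The compounds below may be only part of what the source reports. "The series", "measured", "known", "first", "only" and "open" are said of these compounds alone.

Compound 2, `CCc1ccc2[nH]c(=O)c(CN(Cc3ccc(F)cc3)Cc3ccc(C(C)(C)C)cc3)cc2c1`, is the starting point. In a toxicity assay on MDCK cells (Canis lupus familiaris) for cytotoxicity, read by crystal violet staining, with a stated time of 48 h (a higher number here means that more compound is tolerated, a lower number that less compound is tolerated), compound 2 reaches only a limit of the assay, > 33000 nM. Its closest measured neighbour is compound 1, `Cc1ccc2[nH]c(=O)c(CN(Cc3ccc(F)cc3)Cc3ccc(C(C)(C)C)cc3)cc2c1`, which differs from it by a methyl in place of hydrogen on a saturated chain carbon bound to an aromatic carbon. In this assay compound 1 likewise reaches only a limit, > 27000 nM. The step that the two limits leave unreadable from compound 1 to compound 2 cannot be read because both values sit at limits, the limit of > 27000 nM in this assay, at which 1 of the 2 values shown sits, and (the limit of > 33000 nM in this assay, at which 1 of the 2 values shown sits). Compound 3, `CCc1ccc2[nH]c(=O)c(CN(Cc3ccc(C(C)(C)C)cc3)Cc3ccc(F)c(F)c3)cc2c1`, carries a different change: fluoro in place of hydrogen on an aromatic carbon, a fluoro in place of hydrogen on an aromatic carbon. Within the data shown here, no measured step covers a change of this kind. With both known values at limits, the expected step that the limit leaves unreadable from compound 2 to compound 3 is none beyond the scatter. Compound 3 is therefore expected to give 40000 nM in this assay, within a range from 20000 nM to 100000 nM.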

Compound 3, half-maximal cytotoxic concentration: > 33000 nM
Compound 3 ended at the assay's limit (the forecaster's own chance of this, stated with the estimate: 80%); the middle value lies beyond the limit too.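

Compound 2 and compound 3 both stop at a limit of this assay, so no step between them can be read: the limit of > 33000 nM in this assay, at which 2 of the 3 values shown sit.

The compounds shown leave open whether the added fluoro shifts the half-maximal cytotoxic concentration at all, and where the true values of all three compounds lie.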